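From butylcarbonyl to (chloromethyl)carbonyl on the shared core

This account rests on a few compounds, and the source may have more. Where it says the series, first, only, none or still open, it means among the compounds named here.

In a functional assay on A-375 cells (Homo sapiens) for cytotoxicity, read by MTT assay (a lower number here means a stronger inhibitor, a higher number a weaker inhibitor), compound 3 `CCCCC(=O)Oc1cc(/C=C/C(=O)c2ccc(OC)c3c2OC(C)(C)C=C3)ccc1OC` gives 220 nM, the lowest number among the measured compounds. Its nearest neighbour, compound 2 `COc1ccc(/C=C/C(=O)c2ccc(OC)c3c2OC(C)(C)C=C3)cc1OCCCN(C)C`, gives 4100 nM. Compound 1 `C=CCOc1cc(/C=C/C(=O)c2ccc(OC)c3c2OC(C)(C)C=C3)ccc1OC` reaches only a limit of the assay, > 10000 nM.

Compound 4 `COc1ccc(/C=C/C(=O)c2ccc(OC)c3c2OC(C)(C)C=C3)cc1OC(=O)CCl` keeps the shared core and differs from compound 3 in one place: chloro in place of propyl on a saturated chain carbon bound to a carbonyl carbon. Put in words, this is chloro in place of propyl on a saturated chain carbon bound to a carbonyl carbon, so butylcarbonyl becomes (chloromethyl)carbonyl.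

Within the data shown here, two measured steps bear on this change, and both are large: a 19-fold lower number from compound 2 to compound 3 (1.27 log units; beyond the scatter), and an at least 45-fold lower number from compound 1 to compound 3 (1.65 log units; beyond the scatter). Each puts butylcarbonyl on an oxygen on an aromatic ring, in place of 3-(dimethylamino)propyl or allyl. Compound 4 keeps a carbonyl on that oxygen, so it is expected to hold most of the gain seen in a 19-fold lower number from compound 2 to compound 3 (1.27 log units; beyond the scatter). Among the measured compounds shown here, no measured pair alters the chain on that carbonyl, however, so the size of the new step remains uncertain. A small move toward a higher number is expected in this assay, namely a 1.6-fold higher number from compound 3 to compound 4 (0.20 log units; within the scatter). For compound 4 the estimated value is 350 nM, with an expected range from 100 nM to 1500 nM.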

Compound 4, half-maximal inhibitory concentration: 450 nM
Estimate against measurement, compound 4: 1.3-fold (0.11 log units) below; the range from low to high includes it.
By their numbers in this assay, from the lowest: compound 3; then compound 4; then compound 2. At a limit, above all of these: compound 1.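

In this assay, the chain on the carbonyl is not a silent part of the molecule: chloro in place of propyl on a saturated chain carbon bound to a carbonyl carbon gives a 2.0-fold higher number from compound 3 to compound 4 (0.31 log units; beyond the scatter), a step that is modest but beyond the scatter. The carbonyl on the oxygen still accounts for most of the difference from the compounds without it, since (chloromethyl)carbonyl in place of 3-(dimethylamino)propyl gives a 9.1-fold lower number from compound 2 to compound 4 (0.96 log units; beyond the scatter), and in place of allyl gives an at least 22-fold lower number from compound 1 to compound 4 (1.34 log units; beyond the scatter). Compound 1 sits at a limit of the assay rather than at a number, so that last step gives only a minimum size: the limit of > 10000 nM in this assay, at which 1 of the 4 values shown sits.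

This single step replaces propyl with chloro, so it cannot separate the loss of the propyl chain from the arrival of the chlorine. On these data alone, how the number would respond to a plain methyl, a fluoro, an amine or a longer chain on that same saturated chain carbon stays open, as does whether compound 4 and compound 3 would keep their order in any other assay.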